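Swapping a methoxy for a fluoro on a second core

The compounds below may be only part of what the source reports. "The series", "measured", "known", "first", "only" and "open" are said of these compounds alone.

Measured compounds:
- compound 1, `COc1cc(C=C(C(=O)/C=C/c2cccc(OC)c2OC)C(=O)/C=C/c2cccc(OC)c2OC)ccc1O`, 200 nM
- compound 2, `COc1cccc(/C=C/C(=O)C(=Cc2ccc(O)c(F)c2)C(=O)/C=C/c2cccc(OC)c2OC)c1OC`, 220 nM
- compound 3, `COc1ccc(/C=C/C(=O)C(=Cc2ccc(O)c(OC)c2)C(=O)/C=C/c2ccc(OC)cc2OC)c(OC)c1`, 510 nM

All three were tested in a functional assay on HepG2 cells (Homo sapiens) for antiproliferative activity, read by sulforhodamine B assay, with a stated time of 48 h; on this read-out higher numbers stand for weaker inhibition and lower numbers for stronger inhibition. Compound 1 and compound 2 share one core; compound 3 has a core built from the same atoms joined differently, and how the two cores differ is not broken down here. Compound 3 gives the highest number of the three, with compound 2 and compound 1 both well beyond the scatter below it.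

Compound 1 and compound 2 differ in one place: fluoro in place of methoxy on an aromatic carbon. That step changed the read-out by a 1.1-fold higher number from compound 1 to compound 2 (0.04 log units; within the scatter), a step that does not rise above the noise of repeated measurements.

Compound 4, `COc1ccc(/C=C/C(=O)C(=Cc2ccc(O)c(F)c2)C(=O)/C=C/c2ccc(OC)cc2OC)c(OC)c1`, has not been measured. It stands to compound 3 as compound 2 stands to compound 1: fluoro in place of methoxy on an aromatic carbon. The place lines of the two changes read the same word for word, so this is the same change, made on the core of compound 3.

Because the earlier step was a 1.1-fold higher number from compound 1 to compound 2 (0.04 log units; within the scatter), compound 4 is expected to sit close to compound 3, with an estimated step of a 1.1-fold higher number from compound 3 to compound 4 (0.03 log units; within the scatter). The expectation rests on a single earlier pair on a different core, so the range is kept fairly wide. Compound 4 is estimated at 550 nM, somewhere between 280 nM and 1100 nM.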

Compound 4, half-maximal inhibitory concentration: 1760 nM
Estimate against measurement, compound 4: 3.2-fold (0.51 log units) below; the measured number lies above the stated range.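

In this assay, the change from 4-hydroxy-3-methoxyphenyl to 3-fluoro-4-hydroxyphenyl did not behave on the core of compound 3 as it did on the core of compound 1: here it gave a 3.5-fold higher number from compound 3 to compound 4 (0.54 log units; beyond the scatter), which means clearly weaker inhibition. Set side by side, the two results show that the effect of this swap did not carry over from one core to the other, so a step that looked harmless on the first core was a poor guide to the second: the same change on two cores in this assay, a 1.1-fold higher number (0.04 log units; within the scatter) from compound 1 to compound 2 and a 3.5-fold higher number (0.54 log units; beyond the scatter) from compound 3 to compound 4, 3.1-fold (0.50 log units) apart, beyond the scatter of two such steps They do not show why the two cores respond differently, and with a single pair on each core, they cannot say how the same swap would behave on a further core.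

The compounds shown leave open whether the weaker inhibition on the core of compound 3 comes from fluoro entering or from methoxy leaving, a question that a chloro or ethoxy group in the same place on that core could help to settle. Also open, from the compounds shown here alone, is how each core would respond if an amino group took the place of the hydroxy group.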